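Taking one chloro off compound 3

The compounds below may be only part of what the source reports. "The series", "measured", "known", "first", "only" and "open" are said of these compounds alone.

Of the compounds shown here, three sharing one core have been measured so far. In a functional assay on U-87MG ATCC cells for antiproliferative activity against U-87 MG (Homo sapiens), read by MTT assay, with a stated time of 48 h (a lower number here means a stronger inhibitor, a higher number a weaker inhibitor), compound 1 (`COc1ccc(-c2nc(SCC(=O)c3sc(-c4ccccc4)nc3C)[nH]c(=O)c2C#N)cc1`) gives 48400 nM, compound 2 (`COc1cccc(-c2nc(SCC(=O)c3sc(-c4ccccc4)nc3C)[nH]c(=O)c2C#N)c1`) gives 59700 nM and compound 3 (`Cc1nc(-c2ccc(Cl)cc2)sc1C(=O)CSc1nc(-c2cccc(Cl)c2)c(C#N)c(=O)[nH]1`) gives 40100 nM. These three numbers lie within the usual scatter of one another, so compound 3 stands level with the other two.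

Compound 4 (`Cc1nc(-c2ccccc2)sc1C(=O)CSc1nc(-c2cccc(Cl)c2)c(C#N)c(=O)[nH]1`) has hydrogen in place of chloro on an aromatic carbon, turning 4-chlorophenyl into phenyl: hydrogen in place of chloro on an aromatic carbon. Among the compounds with values here, no measured step makes this exact change. Within the data shown here, the only measured step moves a methoxy group elsewhere in the molecule, a 1.2-fold higher number from compound 1 to compound 2 (0.09 log units; within the scatter), so it bears on this change only loosely. The phenyl that compound 4 gains is already present in compound 1, at 48400 nM, though that compound also differs elsewhere. Its number lies within the scatter of compound 3. No step beyond the scatter is therefore expected in this assay. The estimated step is a 1.1-fold higher number from compound 3 to compound 4 (0.05 log units; within the scatter). For compound 4 the expected value is 45000 nM, with an estimated range of 25000 nM to 80000 nM.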

Compound 4, half-maximal inhibitory concentration: 28200 nM
The estimate for compound 4 lay 1.6-fold (0.20 log units) above the measured number, and the stated range covers the measured number.
By their numbers in this assay, from the lowest: compounds 4, 3, 1 and 2 (each within the scatter of the next, the first and the last beyond it).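

In this assay, the 4-chlorophenyl of compound 3 can give way to phenyl without a clear effect, with a 1.4-fold lower number from compound 3 to compound 4 (0.15 log units; within the scatter), so the chloro at this position is not needed to keep this level of activity. Within the data shown here, the new compound also gives the first step beyond the scatter, though a modest one: with chloro in place of methoxy on an aromatic carbon, the result is a 2.1-fold lower number from compound 2 to compound 4 (0.33 log units; beyond the scatter), while 3-chlorophenyl in place of 4-methoxyphenyl gives a 1.7-fold lower number from compound 1 to compound 4 (0.23 log units; within the scatter). Nothing available explains these numbers.

As far as these compounds go, whether a different kind of group at this position, such as an amine or a carboxylic acid, would shift the number beyond the scatter remains open. So does whether removing the chloro would read the same with a methoxyphenyl on the other side of the molecule.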